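The source may hold more compounds than are shown below. What is called first, only, known or untested is meant among the compounds shown, and "the series" means these compounds.

Compound 1 `CC1CCN(c2nc(C(F)(F)F)ccc2CNC(=O)Nc2ccc3ccncc3c2)CC1` gives 8.4 nM in an assay on isolated protein for antagonist activity at transient receptor potential cation channel subfamily V member 1 (Homo sapiens), read by FLIPR; a lower number here means a stronger inhibitor, a higher number a weaker inhibitor; compound 2 `CC1CCN(c2nc(C(F)(F)F)ccc2CNC(=O)Nc2cccc3cccnc23)CC1` gives 91.6 nM; compound 3 `CC1CCN(c2nc(C(F)(F)F)ccc2CNC(=O)Nc2cncc3ccccc23)CC1` gives 1.8 nM.

Among these three numbers compound 1 stands second highest: compound 3 lies below it, compound 2 above it, both beyond the scatter. Compound 4 `CC1CCN(c2nc(C(F)(F)F)ccc2CNC(=O)Nc2nccc3ccccc23)CC1` differs from compound 1 by isoquinolin-1-yl in place of isoquinolin-7-yl on an amide-type nitrogen. Among the measured compounds shown here, two measured steps bear on this change, each also a rearrangement of the same two-ring group on the urea nitrogen: a 4.7-fold lower number from compound 1 to compound 3 (0.67 log units; beyond the scatter) and an 11-fold higher number from compound 1 to compound 2 (1.04 log units; beyond the scatter). They point in opposite directions, so such rearrangements can move the number a lot either way. For the measured compounds named here, with no closer precedent, a modest step is expected, leaning toward a somewhat higher number: a 1.8-fold higher number from compound 1 to compound 4 (0.25 log units; within the scatter). Compound 4 is therefore estimated at 15 nM, within 3 nM to 75 nM.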

Compound 4, inhibition constant: "not active" (no number reported)
Nothing numeric was reported for compound 4; the estimate stays without a comparison.
By their numbers in this assay, from the lowest: compound 3; then compound 1; then compound 2.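

Among the compounds shown here, compound 4 is reported as "not active" without a number, so no step between it and compound 1, compound 2 or compound 3 can be read. From the compounds shown here alone, how far compound 4 lies from the others in this assay stays open. Nothing shown here explains this result.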